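The compounds below may be only part of what the source reports. "The series", "measured", "known", "first", "only" and "open" are said of these compounds alone.

Compound 1 `Cn1cc(-c2ccccc2Oc2ccccc2)c2cc(C(=O)NCCCCCCC(=O)NO)[nH]c2c1=O` and compound 2 `Cn1cc(-c2ccccc2Oc2ccccc2)c2cc(C(=O)NCc3ccc(C(=O)NO)cc3)[nH]c2c1=O` share one core and differ only at the end of the side chain; compound 3 `Cn1cc(-c2cc(C(C)(C)O)ccc2Oc2ccc(F)cc2F)c2cc(C(=O)NCc3ccc(C(=O)NO)cc3)[nH]c2c1=O` carries the same side chain as compound 2 on a second core, and the difference between the two cores is not broken down here. In an assay on isolated protein for inhibition of protein deacetylase HDAC6 (Homo sapiens), read by fluorescence (a lower number here means a stronger inhibitor, a higher number a weaker inhibitor), compound 1 gives 4.7 nM, compound 2 gives 15.3 nM, and compound 3 gives 15.6 nM. The values of compound 2 and compound 3 lie within the scatter of each other, so the second core does not show a separate effect in this assay. The change 5-(hydroxycarbamoyl)pentyl in place of 4-(hydroxycarbamoyl)phenyl on a saturated chain carbon bound to an amide-type nitrogen gave a 3.3-fold lower number from compound 2 to compound 1 (0.51 log units; beyond the scatter). Compound 4 `Cn1cc(-c2cc(C(C)(C)O)ccc2Oc2ccc(F)cc2F)c2cc(C(=O)NCCCCCCC(=O)NO)[nH]c2c1=O` applies the same change 5-(hydroxycarbamoyl)pentyl in place of 4-(hydroxycarbamoyl)phenyl on a saturated chain carbon bound to an amide-type nitrogen to compound 3, at the same place. Because the step from compound 2 to compound 1 was a 3.3-fold lower number from compound 2 to compound 1 (0.51 log units; beyond the scatter), and because compound 3 in this assay gives 15.6 nM, a step of similar size is expected from compound 3 to compound 4, about a 2.8-fold lower number from compound 3 to compound 4 (0.45 log units; beyond the scatter). This rests on a single measured pair, so the expected range is kept wide. Compound 4 is therefore estimated at 5.5 nM in this assay, between 2.5 nM and 12 nM.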

Compound 4, half-maximal inhibitory concentration: 8.7 nM
Compound 4: middle estimate off by 1.6-fold (0.20 log units), on the low side; measured number inside the range.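

In this assay, moving to the 5-(hydroxycarbamoyl)pentyl chain on the core of compound 3 gave a 1.8-fold lower number from compound 3 to compound 4 (0.25 log units; within the scatter), so this step alone does not separate the two side chains on that core. Set beside the earlier step, the two results do not differ measurably: the same change on two cores in this assay, a 3.3-fold lower number (0.51 log units; beyond the scatter) from compound 2 to compound 1 and a 1.8-fold lower number (0.25 log units; within the scatter) from compound 3 to compound 4, 1.8-fold (0.26 log units) apart, within the scatter of two such steps. The change is therefore compatible with carrying over from one core to the other, but this is not shown: the step lies beyond the scatter on the core of compound 1 and within it on the core of compound 3, and two pairs establish no rule for the series.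

The compounds shown leave open whether a longer chain than 6-(hydroxycarbamoyl)hexyl, or a carboxylic acid in place of the hydroxycarbamoyl end, would give a similar result in this assay. They also leave open how either side chain would read on a third core.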